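Swapping a Difluoromethoxy Chain End for Methylsulfonyl

This account rests on a few compounds, and the source may have more. Where it says the series, first, only, none or still open, it means among the compounds named here.

Measured so far in a physicochemical assay for lipophilicity, read by spectrophotometry, using the shake flask method, measured as octanol-water partition; on this read-out lower numbers stand for lower lipophilicity and higher numbers for higher lipophilicity:
compound 1 `O=[N+]([O-])c1ccc(C(F)F)cc1`: 2.12
compound 2 `N#Cc1ccc(C(F)F)cc1`: 1.75
compound 3 `FC(F)OCCc1ccccc1`: 3.16

Compound 3 stands highest of the three numbers in this assay. Its nearest neighbour on this scale is compound 1, which sits lower, and compound 2 lies furthest below it; both gaps are beyond the scatter. Among the compounds with values here, the only step between measured compounds that differ in one place is a number 0.37 log units lower from compound 1 to compound 2 (beyond the scatter), a modest drop on the aromatic ring of that pair.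

Compound 4 `CS(=O)(=O)CCc1ccccc1` is the next compound to be measured. The change from compound 3 is methylsulfonyl in place of difluoromethoxy on a saturated chain carbon, two bonds along the chain from an aromatic carbon. Within the data shown here, no measured step touches this saturated chain or either of the two groups involved, so the step from compound 1 to compound 2 bears on it only loosely, as an example that exchanging one small group for another of similar size can move the number by a modest amount. On the structures alone, a larger fall is expected here, with a number 2.16 log units lower from compound 3 to compound 4 (beyond the scatter) as the estimated step. Compound 4 is therefore expected to give about 1 in this assay, with a plausible range from 0.5 to 1.5.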

Compound 4, partition coefficient: 0.82
Compound 4: middle estimate off by 0.18 log units, on the high side, within the range that was stated.
By their numbers in this assay, from the lowest: compound 4; then compound 2; then compound 1; then compound 3.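

In this assay, putting methylsulfonyl in place of difluoromethoxy on a saturated chain carbon, two bonds along the chain from an aromatic carbon, gives a number 2.34 log units lower from compound 3 to compound 4 (beyond the scatter), a large step that shows this position can carry a strong change in the number. The two groups have 4 heavy atoms each, so this step arises with no change in that count, and it is far larger than the modest a number 0.37 log units lower from compound 1 to compound 2 (beyond the scatter), though that pair differs at an aromatic carbon and not on this chain. Within the data shown here, no measurement at hand explains why the exchange moves the number so far.

The compounds shown leave open how much of this step belongs to the saturated chain itself: a longer chain carrying methylsulfonyl, or the same exchange made directly on an aromatic carbon, could give a different result. They also leave open where a methoxy group, a trifluoromethyl group or a primary sulfonamide at the same place would fall relative to these two groups on this scale.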